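Hydroxy additions on the shared core: permeability notes

The source may hold more compounds than are shown below. What is called first, only, known or untested is meant among the compounds shown, and "the series" means these compounds.

- Compound 1 `Oc1ccc(-c2cc3ccccc3o2)c2cccnc12` gives 4.3 10^-6 cm/s
- Compound 2 `Oc1ccc2cc(-c3ccc(O)c4ncccc34)oc2c1` gives 15.8 10^-6 cm/s

In an ADME assay for permeability, using PAMPA, with a stated time of 10 h, tested at 100 ug/mL (a higher number here means that the compound crosses the layer faster, a lower number that the compound crosses the layer more slowly), compound 2 stands highest of the two measured compounds, with compound 1 lower by more than the scatter. Compound 3 `Oc1cc(O)c2cc(-c3ccc(O)c4ncccc34)oc2c1` differs from compound 2 by hydroxy in place of hydrogen on an aromatic carbon with the new hydroxy meta to a hydroxy group. Going by the values given here, the only measured step of this kind is a 3.7-fold higher number from compound 1 to compound 2 (0.57 log units; beyond the scatter) and it was modest. That single step, at a different carbon, gives weak guidance, so no step beyond the scatter is expected. The expected move is a 1.2-fold lower number from compound 2 to compound 3 (0.08 log units; within the scatter) in this estimate. Compound 3 is estimated at 13 10^-6 cm/s with an expected range of 4.5 10^-6 cm/s to 35 10^-6 cm/s for now.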

Compound 3, apparent permeability: 2.6 10^-6 cm/s
For compound 3 the middle estimate is 5.0-fold (0.70 log units) above the measured one, outside the stated range (below it).
By their numbers in this assay, from the lowest: compounds 3 and 1 (each within the scatter of the next); then compound 2.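

The same change, hydroxy in place of hydrogen on an aromatic carbon, runs in opposite directions in this assay: with the new hydroxy meta to a hydroxy group it gives a 6.1-fold lower number from compound 2 to compound 3 (0.78 log units; beyond the scatter), against a 3.7-fold higher number from compound 1 to compound 2 (0.57 log units; beyond the scatter) at a different carbon. The direction of this change is therefore not constant across the two steps shown. The data at hand offer no explanation for the new step.

From the compounds shown here alone, whether the carbon itself or the hydroxy group already on that ring sets the direction remains open. Going by these compounds, how an amine or a methoxy group at this carbon would read in this assay also remains open.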